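This account rests on a few compounds, and the source may have more. Where it says the series, first, only, none or still open, it means among the compounds named here.

Measured compounds in a functional assay with Rattus norvegicus as the target; on this read-out higher numbers stand for weaker inhibition and lower numbers for stronger inhibition:
compound 1, `COc1cc(C(=O)/C=C/c2ccncc2)cc(OC)c1OC`, gives 7000 nM
compound 2, `N#Cc1cccc(C(=O)/C=C/c2ccncc2)c1`, gives 85000 nM
compound 3, `COc1cc(C(=O)/C=C(\C)c2ccncc2)cc(OC)c1OC`, is reported only as a limit of the assay, > 100000 nM

Among the two numbers in hand in this assay, compound 2 stands highest; its nearest neighbour is compound 1, which sits lower by a gap beyond the usual scatter of repeat measurements. For compound 3 the read-out is a limit and not a number, (the limit of > 100000 nM in this assay, at which 1 of the 3 values shown sits). Among the measured compounds shown here, no two of the measured compounds differ from one another in a single place, so no measured step between them is available to lean on.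

Compound 4, `Cc1cccc(C(=O)/C=C/c2ccncc2)c1`, is not yet measured in this assay. It differs from compound 2 in one place: methyl in place of cyano on an aromatic carbon. For the measured compounds named here, nothing among the measured compounds shows what this exchange does to the read-out, and the series gives no basis for a direction. The step is therefore expected to be no larger than the scatter, in either direction.

Compound 4 is estimated at 60000 nM, with a range from 15000 nM to 200000 nM. The step that this estimate means, a 1.4-fold lower number from compound 2 to compound 4 (0.15 log units; within the scatter), is expected to fall within the usual scatter.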

Compound 4, half-maximal inhibitory concentration: 39000 nM
Estimate against measurement, compound 4: 1.5-fold (0.19 log units) above; the range from low to high includes it.
By their numbers in this assay, from the lowest: compound 1; then compound 4; then compound 2. At a limit, above all of these: compound 3.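

In this assay, the exchange of cyano for methyl gives the series its first measured single-place step: a 2.2-fold lower number from compound 2 to compound 4 (0.34 log units; beyond the scatter). The read-out at this aromatic carbon therefore responds to the group placed there, though only modestly, with the number lower for methyl, which carries no hydrogen-bond acceptor and has one heavy atom in place of two. The change leaves both compounds in the same high range, with compound 2 at 85000 nM and compound 4 at 39000 nM, and nothing at hand on the properties of either group bears on the reason for the step.

On these data alone, with only cyano and methyl compared at this place, the two points fix a direction for this one pair but no trend, so whether an amine, a carboxylic acid, a chlorine atom or a longer chain such as propyl would extend the shift or reverse it remains open. Also open, as far as these compounds go, is whether the same exchange gives a step of similar size on the core of compound 1, or with the methyl moved to another carbon of the ring.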